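A few compounds are considered here, and "the series" means these few. Any claim that something is new, unique, unknown or untested is made for them only; others in the source may bear on it.

Measured so far in an assay for binding affinity to dual specificity mitogen-activated protein kinase kinase 4 (Homo sapiens), read by KINOMEscan, tested at 100 nM; on this read-out lower numbers stand for a stronger effect and higher numbers for a weaker effect at the one concentration tested:
compound 1, `CCCS(=O)(=O)Nc1ccc(F)c(C(=O)c2n[nH]c3ncc(-c4ccc(F)cc4)cc23)c1F`, gives 2.1%;
compound 2, `CCCS(=O)(=O)Nc1ccc(F)c(C(=O)c2n[nH]c3ncc(-c4ccc(N)cc4)cc23)c1F`, gives 0.1%;
compound 3, `CCCS(=O)(=O)Nc1ccc(F)c(C(=O)c2n[nH]c3ncc(-c4ccc([N+](=O)[O-])cc4)cc23)c1F`, gives 4.2%.

All three share one core and differ only in the group on the outer benzene ring. On the numbers shown, compound 3 has the largest reading of the three, but this means little: the step of a number 2.1 percentage points higher from compound 1 to compound 3 (within the scatter) and the step of a number 4.1 percentage points higher from compound 2 to compound 3 (within the scatter) are both within the scatter, as is the step of a number 2 percentage points lower from compound 1 to compound 2 (within the scatter). The three compounds are therefore not told apart by this assay.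

Compound 4, `CCCS(=O)(=O)Nc1ccc(F)c(C(=O)c2n[nH]c3ncc(-c4ccc(S(=O)(=O)NC(C)=O)cc4)cc23)c1F`, continues this series with acetylsulfamoyl in place of nitro on an aromatic carbon. Among the compounds with values here, the same position has already carried fluoro, amino and nitro without any step beyond the scatter, so the only guide available points to no step of note in this assay for this change either. The new group is larger than any tried so far, which widens the uncertainty but gives no direction. The expected step of a number 1.2 percentage points lower from compound 3 to compound 4 (within the scatter) is thus small. Compound 4 is estimated to give 3%, with a range from 0.3% to 15%.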

Compound 4, a percentage reported as activity, at one concentration (the size of the read-out at that concentration, not a potency): 0.35%
Compound 4: the middle estimate sits 2.7 percentage points above what was measured; the measured number falls inside the stated range.
By their numbers in this assay, from the lowest: compounds 2, 4, 1 and 3 (each within the scatter of the next).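

Acetylsulfamoyl has 7 heavy atoms where nitro has 3, and it brings 1 hydrogen-bond donor where nitro has none, yet in this assay the change gives a number 3.9 percentage points lower from compound 3 to compound 4 (within the scatter) and the comparisons with the other two groups give a number 0.3 percentage points higher from compound 2 to compound 4 (within the scatter) and a number 1.8 percentage points lower from compound 1 to compound 4 (within the scatter) without any step beyond the scatter. This position therefore carries a much larger group than fluoro, amino or nitro, and the four compounds remain untold apart by this read-out. No measurement at hand explains this result.

From the compounds shown here alone, whether a carboxylic acid or a piperazine ring at this position would also stay within the scatter remains open. Also open is whether real differences in potency exist among these four compounds, since a reading at one concentration cannot show them.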